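The source may hold more compounds than are shown below. What is called first, only, known or untested is meant among the compounds shown, and "the series" means these compounds.

Series in a functional assay on Bel-7402 cells (Homo sapiens) for antiproliferative activity, read by MTT assay, with a stated time of 72 h; on this read-out lower numbers stand for stronger inhibition and higher numbers for weaker inhibition:

- compound 1 `C=C1C(=O)O[C@H]2[C@H]1CC/C(COC(=O)CCC(=O)NCCCCCCNC(=O)Cn1cc(F)c(=O)[nH]c1=O)=C\CC[C@@]1(C)O[C@@H]21` gives > 20000 nM, which is a limit of the assay
- compound 2 `C=C1C(=O)O[C@H]2[C@H]1CC/C(COC(=O)CCC(=O)NCCCCCCNC(=O)Cn1cc(F)c(=O)n(Cc3ccccc3)c1=O)=C\CC[C@@]1(C)O[C@@H]21` gives 18300 nM
- compound 3 `C=C1C(=O)O[C@H]2[C@H]1CC/C(COC(=O)Cn1cc(F)c(=O)n(Cc3ccc(C(F)(F)F)cc3)c1=O)=C\CC[C@@]1(C)O[C@@H]21` gives 2250 nM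

Compound 3 at 2250 nM carries the lowest number of the series. The nearest number, higher by a gap that lies beyond the scatter, belongs to compound 2 at 18300 nM.

Compound 4 `C=C1C(=O)O[C@H]2[C@H]1CC/C(COC(=O)Cn1cc(F)c(=O)n(Cc3cc(F)ccc3F)c1=O)=C\CC[C@@]1(C)O[C@@H]21` has not yet been measured in this assay. It differs from compound 3 by 2,5-difluorophenyl in place of 4-(trifluoromethyl)phenyl on a saturated chain carbon bound to an aromatic nitrogen.

Among the compounds with values here, only one measured step comes near this site: an at least 1.0-fold lower number from compound 1 to compound 2 (0.03 log units; that floor lies within the scatter), with benzyl in place of hydrogen on an aromatic nitrogen. That step starts from a limit, and it adds the benzyl group without changing what the group carries. Within the data shown here, it therefore gives no size for the exchange at hand, and no measured step compares these two groups.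

The expectation rests on compound 3 at 2250 nM as the anchor, with only a small shift. The expected change is a 1.3-fold higher number from compound 3 to compound 4 (0.12 log units; within the scatter), with the direction weakly held. For compound 4 the estimated value is 3000 nM, with an expected range from 1000 nM to 9000 nM.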

Compound 4, half-maximal inhibitory concentration: 3060 nM
Estimate against measurement, compound 4: 1.0-fold (0.01 log units) below; the measured number falls inside the stated range.
By their numbers in this assay, from the lowest: compounds 3 and 4 (each within the scatter of the next); then compound 2. At a limit, above all of these: compound 1.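

In this assay, within the data shown here, 2,5-difluorobenzyl in place of 4-(trifluoromethyl)benzyl gives a 1.4-fold higher number from compound 3 to compound 4 (0.13 log units; within the scatter), the first reading of a change in what the benzyl group carries rather than of its presence. Within this pair, the number does not separate the two groups, so the position accepts either one without a change beyond the scatter; this holds for these two groups only and sets no trend for others. Nothing measured on hand bears on why the two groups read alike.

Still open, from the compounds shown here alone, is whether an amine or a carboxylic acid on the phenyl ring, or a longer chain in place of the benzyl link, would move the number beyond the scatter. Compound 2 and compound 3 differ in more than one place, so the share of the long amide-bearing linker and the share of the trifluoromethyl group in the gap between them cannot be told apart.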